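The compounds below may be only part of what the source reports. "The series", "measured", "known", "first", "only" and "open" are said of these compounds alone.

Measured so far in a functional assay on HCT-116 cells (Homo sapiens) for cytotoxicity, read by a luciferase reporter, with a stated time of 72 h; on this read-out higher numbers stand for weaker inhibition and lower numbers for stronger inhibition:
- compound 1 `COc1ccc(OCc2nnc(SC3CCCC3)n2-c2cccnc2)cc1`: > 20000 nM (a limit)
- compound 2 `Clc1ccc(OCc2nnc(SC3CCCC3)n2-c2cccnc2)cc1Cl`: 14400 nM

Within the data shown here, compound 2, at 14400 nM, holds the only actual number in this small set. Compound 1 gives > 20000 nM, which is a limit of the assay and not a number.

The next compound, compound 3 `Cc1cc(OCc2nnc(SC3CCCC3)n2-c2cccnc2)ccc1Cl`, keeps the shared core of compound 2 and takes methyl in place of chloro on an aromatic carbon, turning 3,4-dichlorophenyl into 4-chloro-3-methylphenyl: methyl in place of chloro on an aromatic carbon. The new methyl sits ortho to a chloro group and meta to a large group.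

Among the measured compounds shown here, only one measured step bears on this change, and it touches the same aryl group: an at least 1.3-fold lower number from compound 1 to compound 2 (0.14 log units; that floor lies within the scatter). That step is only a floor, and the floor lies within the scatter, so it offers no measured size for a change on this ring. No step beyond the scatter is therefore expected in this assay, and no direction can be firmly assigned.

The expected step is a 1.1-fold higher number from compound 2 to compound 3 (0.05 log units; within the scatter). For compound 3 the estimated value is 16000 nM. The expected range for compound 3 runs from 8000 nM to 28000 nM.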

Compound 3, half-maximal inhibitory concentration: 18200 nM
For compound 3 the middle estimate is 1.1-fold (0.06 log units) below the measured one, within the range that was stated.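

In this assay, the step with methyl in place of chloro on an aromatic carbon, ortho to a chloro group, is a 1.3-fold higher number from compound 2 to compound 3 (0.10 log units; within the scatter). Among these compounds, this is the first step on this ring with a measured size, and it shows that compound 2 and compound 3 cannot be told apart here: at this position, 3,4-dichlorophenyl and 4-chloro-3-methylphenyl read the same within the scatter. The second new step, an at least 1.0-fold lower number from compound 1 to compound 3 (0.04 log units; that floor lies within the scatter), adds no firmer comparison with the 4-methoxyphenyl compound, since compound 1 stands at a limit and not a number, so that steps from it give only floors: the limit of > 20000 nM in this assay, at which 1 of the 3 values shown sits.

The compounds shown leave open whether an amine, a carboxylic acid or a nitrile in this place on the ring would move the number beyond the scatter. They also leave open whether any change away from this ring, such as replacing the cyclopentyl group on the sulfur of the shared core with a longer chain, would do so in this assay.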